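Chain Lengthening on Two Cores Leaves Inhibition Unchanged

This account rests on a few compounds, and the source may have more. Where it says the series, first, only, none or still open, it means among the compounds named here.

Four compounds carry a ((iodomethyl)carbonyl)amino end group on a flexible chain attached to a nucleotide-like core. Compound 1 `O=C(CI)NCCCCC(=O)NCCCCCCNc1ncnc2c1ncn2[C@@H]1O[C@H](COP(=O)(O)OP(=O)(O)OP(=O)(O)O)[C@@H](O)[C@H]1O` and compound 2 `O=C(CI)NCCCCCCC(=O)NCCCCCCNc1ncnc2c1ncn2[C@@H]1O[C@H](COP(=O)(O)OP(=O)(O)OP(=O)(O)O)[C@@H](O)[C@H]1O` share one core, while compound 3 `CN(CCCCN(C)c1ncnc2c1ncn2[C@@H]1O[C@H](COP(=O)(O)OP(=O)(O)OP(=O)(O)O)[C@@H](O)[C@H]1O)C(=O)CCCNC(=O)CI` and compound 4 `CN(CCCCN(C)c1ncnc2c1ncn2[C@@H]1O[C@H](COP(=O)(O)OP(=O)(O)OP(=O)(O)O)[C@@H](O)[C@H]1O)C(=O)CCCCCNC(=O)CI` share another; the difference between the two cores is not broken down here.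

In an assay on isolated protein for inhibition of hexokinase-2 (Rattus norvegicus), with a stated time of 6 h, tested at 10 mM (a lower number here means less inhibition, a higher number more inhibition at the concentration tested (going by the name of the read-out)), compound 1 gives 0%. Compound 2 gives 0% in this assay. The change from compound 1 to compound 2 is 2-(((iodomethyl)carbonyl)amino)ethyl in place of ((iodomethyl)carbonyl)amino on a saturated chain carbon, four bonds along the chain from a carbonyl carbon, and the step it made was no change at the digits printed from compound 1 to compound 2 (within the scatter). Compound 3 gives 0% in this assay, level with the other two at the digits reported.

Compound 4 is reached from compound 3 by 2-(((iodomethyl)carbonyl)amino)ethyl in place of ((iodomethyl)carbonyl)amino on a saturated chain carbon, three bonds along the chain from a carbonyl carbon. Among the compounds with values here, this is the same kind of change as the one between compound 1 and compound 2, but not the same, since the place differs: in the first pair the group sits four bonds along the chain from a carbonyl carbon, in the second pair three bonds along the chain from a carbonyl carbon. The step is expected to be no change at the digits printed from compound 3 to compound 4 (within the scatter) because the matching step on the other core was no change at the digits printed from compound 1 to compound 2 (within the scatter). With compound 3 resting at 0%, nothing in these data points toward a rise, so compound 4 is estimated at 0%, with a likely span from 0% to 10%.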

Compound 4, a percentage reported as inhibition, at one concentration (the size of the read-out at that concentration, not a potency): 0%
The estimate for compound 4 equals the measured number at the digits printed; measured number inside the range.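

In this assay the lengthening of the chain reads no change at the digits printed from compound 3 to compound 4 (within the scatter), and set beside the matching step on the other core it gives the same picture: the same change on two cores in this assay, no change at the digits printed (within the scatter) from compound 1 to compound 2 and no change at the digits printed (within the scatter) from compound 3 to compound 4, 0 percentage points apart, within the scatter of two such steps.
Within these four compounds, then, the change carries from one core to the other with the same outcome, and the step on one core would have served as a fair guide to the step on the other. This does not show that the change is neutral in general, since compound 4 gives 0%, as do the other three compounds, so both steps start from a compound with no inhibition to lose and neither says how the change would act on a compound that does inhibit.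

As far as these compounds go, it remains open whether a longer chain, or an amine or a carboxylic acid in place of the ((iodomethyl)carbonyl)amino end group, would bring any inhibition on either core in this assay. From the compounds shown here alone, it also remains open whether the two cores would differ from each other at all once a compound on one of them gives a read-out that can rise or fall.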